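The source may report more compounds than this note shows. Statements on the series, on what has been measured and on what is new or still open speak of the compounds shown alone.

Measured in a physicochemical assay for lipophilicity, read by HPLC, at pH 7.5; on this read-out higher numbers stand for higher lipophilicity and lower numbers for lower lipophilicity:
- compound 1 `CCc1cc(CC)n2nc(-c3ccc(OC)cc3)c(CC(=O)N(C)C)c2n1`: 2.47
- compound 2 `CCc1cc(CC)n2nc(-c3ccc(OC)cc3)c(CC(=O)N(CC)C(C)(C)C)c2n1`: 3.32

Of these two, compound 2 holds the higher number in this assay. Next in the series is compound 3 `CCc1cc(CC)n2nc(-c3ccc(OC)cc3)c(CC(=O)N3CCCC3)c2n1`, which carries a group of 5 heavy atoms (4 carbon, 1 nitrogen; one five-membered non-aromatic ring with 1 hetero atom) in place of a group of 7 heavy atoms (6 carbon, 1 nitrogen; no ring), on a carbonyl carbon. For the measured compounds named here, one measured step bears on this change: a number 0.85 log units higher from compound 1 to compound 2 (beyond the scatter), a modest rise that came with a larger group on the carbonyl carbon. With a smaller group entering here, a fall is expected, probably smaller than that rise. The expected change is a number 0.52 log units lower from compound 2 to compound 3 (beyond the scatter). For compound 3 the estimate is 2.8, with an expected range from 2.5 to 3.1.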

Compound 3, partition coefficient: 2.72
Compound 3: middle estimate off by 0.08 log units, on the high side; measured number inside the range.
By their numbers in this assay, from the lowest: compounds 1 and 3 (each within the scatter of the next); then compound 2.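

In this assay the change to pyrrolidin-1-yl on the carbonyl carbon gives a number 0.60 log units lower from compound 2 to compound 3 (beyond the scatter) for this amide position. Replacing dimethylamino with the same ring gives a number 0.25 log units higher from compound 1 to compound 3 (within the scatter) and so does not separate these two amides, leaving compound 2 apart from both. Nothing available accounts for these differences. As far as these compounds go, whether a piperidine or morpholine amide would group with compound 1 and compound 3 or with compound 2 remains open, as does the placing of a secondary amide that keeps the amide hydrogen.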